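Indole-oxazole series: aryl swap at the oxazole carbon

A few compounds are considered here, and "the series" means these few. Any claim that something is new, unique, unknown or untested is made for them only; others in the source may bear on it.

The pair in hand shares a core in which an indole is linked to an oxazole that carries a second aryl group. Compound 1 `Fc1ccc(-c2nc(-c3c[nH]c4ccccc34)co2)cc1` carries 4-fluorophenyl there and in a functional assay on PC-3 cells (Homo sapiens) for cytotoxicity, read by MTT assay, with a stated time of 48 h (a lower number here means a stronger inhibitor, a higher number a weaker inhibitor), compound 1 gives 42800 nM. Compound 2 `c1ccc2c(-c3coc(-c4ccncc4)n3)c[nH]c2c1` carries pyridin-4-yl instead, and in this assay compound 2 gives 298000 nM, the highest number of the two measured and the weaker inhibitor. For the measured compounds named here, the one step measured so far, a 7.0-fold higher number from compound 1 to compound 2 (0.84 log units; beyond the scatter), describes that exchange.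

Compound 3 `Clc1ccc(-c2nc(-c3c[nH]c4ccccc34)co2)cc1` differs from compound 2 by 4-chlorophenyl in place of pyridin-4-yl on an aromatic carbon. This is close to the reverse of the measured step: a six-membered all-carbon ring with a halogen replaces the ring nitrogen, as in compound 1. The step from compound 1 to compound 2 was modest but beyond the scatter, so a drop of about that size, to a lower number, is expected for a 9.9-fold lower number from compound 2 to compound 3 (1.00 log units; beyond the scatter). Going by the values given here, compound 3 is therefore estimated at 30000 nM, with a likely range from 10000 nM to 90000 nM, since no measured compound carries a chlorine and the size of any difference from compound 1 is not known.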

Compound 3, half-maximal inhibitory concentration: 151000 nM
The estimate for compound 3 lay 5.0-fold (0.70 log units) below the measured number, and the stated range ends below it.
By their numbers in this assay, from the lowest: compound 1; then compounds 3 and 2 (each within the scatter of the next).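

In this assay, replacing pyridin-4-yl with 4-chlorophenyl on this aromatic carbon gives a 2.0-fold lower number from compound 2 to compound 3 (0.30 log units; within the scatter), so the two groups cannot be told apart here, and a ring of carbon only is not enough to reproduce the number of compound 1. The exchange within the halogenated aryl group, chloro in place of fluoro, gives a 3.5-fold higher number from compound 1 to compound 3 (0.55 log units; beyond the scatter), which is beyond the scatter and shows that the earlier step from 4-fluorophenyl to pyridin-4-yl cannot be read simply as the effect of the ring nitrogen, with compound 1 standing apart from both compound 2 and compound 3 in the numbers shown. No measurement at hand explains either step.

On these data alone, it remains open whether an unsubstituted phenyl, or a phenyl carrying bromo, methoxy or an amine, would read with compound 1 or with compounds 2 and 3 in this assay. Also open, as far as these compounds go, is how a methyl group or a carboxylic acid placed elsewhere on the shared core would read, and whether the gap between fluoro and chloro would persist on such a core.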